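The source may hold more compounds than are shown below. What is called first, only, known or untested is meant among the compounds shown, and "the series" means these compounds.

Measured so far:
compound 1 `COc1c(OCc2nc3ccccc3[nH]2)cc(O)c2c(=O)cc(-c3ccccc3)oc12` — > 100000 nM
compound 2 `COc1c(O)cc(O)c2c(=O)cc(-c3ccc(F)cc3)oc12` — "not determined" (no result reported)
compound 3 `COc1c(O)cc(O)c2c(=O)cc(-c3cccc(F)c3)oc12` — "not determined" (no result reported)

In a functional assay on A549 cells (Homo sapiens) for cytotoxicity, read by MTT assay, with a stated time of 48 h (on this read-out higher numbers stand for weaker inhibition and lower numbers for stronger inhibition), compound 1 gives > 100000 nM, which is a limit of the assay and not a number; it sits at the limit of > 100000 nM in this assay, at which 1 of the 3 values shown sits. Among the measured compounds shown here, compound 2 has no result in this assay, and compound 3 likewise shows "not determined" (no result reported), so no step between measured compounds can be read. Compound 4 `COc1c(OCCCN2CCNCC2)cc(O)c2c(=O)cc(-c3ccccc3)oc12` differs from compound 1 by 2-(piperazin-1-yl)ethyl in place of 1H-benzimidazol-2-yl on a saturated chain carbon bound to an oxygen on an aromatic ring. For the measured compounds named here, with no measured step to lean on, the expected step of an at least 2.5-fold lower number from compound 1 to compound 4 (0.39 log units; beyond the scatter) in this assay is toward stronger inhibition, of moderate size, since the limit on compound 1 leaves any size open. Compound 4 is estimated at 40000 nM, with a range from 8000 nM to 200000 nM.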

Compound 4, half-maximal inhibitory concentration: 10100 nM
Compound 4: middle estimate off by 4.0-fold (0.60 log units), on the high side, and the stated range covers the measured number.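

In this assay, the place on a saturated chain carbon bound to an oxygen on an aromatic ring proves able to move the read-out: 2-(piperazin-1-yl)ethyl in place of 1H-benzimidazol-2-yl gives an at least 9.9-fold lower number from compound 1 to compound 4 (0.99 log units; beyond the scatter) in this series. Compound 4 is the first compound shown with a number. Going by these compounds, the true size of the step stays open, and it can be read only as a lower bound: the limit of > 100000 nM in this assay, at which 1 of the 4 values shown sits.

The piperazine ring and the chain length change together, so their shares cannot be separated. On these data alone, how a morpholine ring or a terminal carboxylic acid on the same chain would read remains open.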